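The source may hold more compounds than are shown below. What is called first, only, known or untested is meant among the compounds shown, and "the series" means these compounds.

Working notes on the series. The shared core is that of compound 1 `Cc1cc(C)c(S(=O)(=O)c2ccc(I)cc2)c(C)c1`, which in an assay on isolated protein for antagonist activity at Rap guanine nucleotide exchange factor 4 (Homo sapiens), read by fluorescence and cAMP accumulation (on this read-out higher numbers stand for weaker inhibition and lower numbers for stronger inhibition), gives 4000 nM. Among the compounds with values here, that is the only number in the set. Compound 2 `Cc1cc(C)c(S(=O)(=O)c2ccc(-c3ccc(F)nc3)cc2)c(C)c1` gives > 300000 nM in this assay, a limit and not a number. Compound 3 `Cc1cc(C)c(S(=O)(=O)c2ccc(OC3CCNCC3)cc2)c(C)c1` likewise gives > 300000 nM in this assay, again a limit. Both measured departures from compound 1 replace the iodo on the aromatic carbon: an at least 75-fold higher number from compound 1 to compound 2 (1.87 log units; beyond the scatter) and an at least 75-fold higher number from compound 1 to compound 3 (1.87 log units; beyond the scatter). Both of these land at the limit of > 300000 nM in this assay, at which 2 of the 3 values shown sit, so their true size is not known. Between the two, a step that the two limits leave unreadable from compound 2 to compound 3.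

Compound 4 `Cc1cc(C)c(S(=O)(=O)c2ccc(OCCN)cc2)c(C)c1` has not been measured. It differs from compound 1 by 2-aminoethoxy in place of iodo on an aromatic carbon. Within the data shown here, the steps that bear on it are the two replacements of the same iodo, toward 6-fluoropyridin-3-yl in compound 2 and toward (piperidin-4-yl)oxy in compound 3, each of which was large and ran to the limit. An oxygen-linked chain carrying an amine resembles the (piperidin-4-yl)oxy case most closely, so a large rise in this assay is expected, with a fair chance that only a limit is returned. The estimated step is a 50-fold higher number from compound 1 to compound 4 (1.70 log units; beyond the scatter). For compound 4 the expected value is 200000 nM, within 30000 nM to 1000000 nM.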

Compound 4, half-maximal inhibitory concentration: > 300000 nM
Compound 4 was reported as a limit (the forecaster's own chance of this, stated with the estimate: 60%); middle value at least 1.5-fold (0.17 log units) away from the limit.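

Working notes, continued. In this assay, 2-aminoethoxy replaces iodo with an at least 75-fold higher number from compound 1 to compound 4 (1.87 log units; beyond the scatter), so a replacement without a ring also gives a large step at this aromatic carbon, whereas both earlier replacements contained a ring. Going by these compounds, compound 4 gives > 300000 nM, a limit and not a number, so the true size of this step is unknown, and the steps from compound 2 and compound 3 to compound 4 cannot be read. Among the four compounds, only the iodo compound 1 gives a number, while the three replacements all end at the same limit: the limit of > 300000 nM in this assay, at which 3 of the 4 values shown sit.

The compounds shown do not separate the effect of losing iodo from the effect of the groups that enter, and a bromo, chloro or methyl group at this position would help to test whether a small substituent keeps a readable value. On these data alone, it also remains open whether the oxygen link can be tolerated without the amine, as a methoxy or ethoxy group would show, or whether an amine on a longer chain changes the outcome.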